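The source may hold more compounds than are shown below. What is called first, only, known or untested is meant among the compounds shown, and "the series" means these compounds.

Compound 1, `COc1cc(OC)c2c(=O)cc(/C=C/c3ccc(Cl)cc3)oc2c1`. In a functional assay on A549 cells (Homo sapiens) for antiproliferative activity, read by MTT assay, with a stated time of 12 h (on this read-out lower numbers stand for stronger inhibition and higher numbers for weaker inhibition), compound 1 gives > 40000 nM, which is a limit of the assay and not a number.
Compound 2, `COc1cc(OC)c2c(=O)cc(/C=C/c3ccc(Br)cc3)oc2c1`. In this assay compound 2 gives > 40000 nM, again a limit and not a number.
Compound 3, `COc1cc(OC)c2c(=O)cc(/C=C/c3ccccc3)oc2c1`. In this assay compound 3 gives 21500 nM.

Among the compounds with values here, compound 3 thus stands as the only compound of the three with a measured number; the other two sit at the limit (the limit of > 40000 nM in this assay, at which 2 of the 3 values shown sit). The steps of an at least 1.8-fold lower number from compound 1 to compound 3 (0.26 log units; that floor lies within the scatter) and an at least 1.8-fold lower number from compound 2 to compound 3 (0.26 log units; that floor lies within the scatter) both replace a halogen on the aromatic ring by hydrogen, and both have floors that lie within the scatter.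

Compound 4, `COc1cc(OC)c2c(=O)cc(/C=C/c3ccncc3)oc2c1`, has not yet been measured. Its change from compound 3 is pyridin-4-yl in place of phenyl on a double-bonded chain carbon bound to a double-bonded chain carbon. Within the data shown here, none of the measured steps touches the ring itself, only substituents on it, so no step bears directly on this change. Without such evidence, for compound 4 no step beyond the scatter is expected, that is a 1.1-fold lower number from compound 3 to compound 4 (0.03 log units; within the scatter). Compound 4 is therefore estimated to give 20000 nM, with a range from 7000 nM to 45000 nM.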

Compound 4, half-maximal inhibitory concentration: > 40000 nM
Compound 4 ended at the assay's limit (the forecaster's own chance of this, stated with the estimate: 35%); middle value at least 2.0-fold (0.30 log units) away from the limit.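

Until now only substituents on the aromatic ring had changed; here the ring itself changes, with pyridin-4-yl bringing a ring nitrogen and a hydrogen-bond acceptor in place of phenyl, and the result is an at least 1.8-fold higher number from compound 3 to compound 4 (0.26 log units; that floor lies within the scatter). This floor lies within the scatter, so the step alone is small evidence, but in this assay the unsubstituted phenyl of compound 3 is now the only group shown at this place with a readable number. The steps from compound 1 and from compound 2 to compound 4 cannot be read, and the limit marks the rest of the series: the limit of > 40000 nM in this assay, at which 3 of the 4 values shown sit.

From the compounds shown here alone, how far the limited compounds lie from compound 3 remains open. Also open, going by these compounds, is whether a phenyl ring carrying an amine or a carboxylic acid would reach a readable number.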